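A Methyl Added to Compound 3: Expected Cell Toxicity

A few compounds are considered here, and "the series" means these few. Any claim that something is new, unique, unknown or untested is made for them only; others in the source may bear on it.

Measured compounds, all read in an ADME assay on L929 cells (Mus musculus) for cytotoxicity, read by resazurin assay, with a stated time of 72 h; on this read-out lower numbers stand for stronger inhibition and higher numbers for weaker inhibition:
compound 1, `OB1OCc2ccc(-n3cccc3)cc21`, gives > 10 ug/mL, which is a limit of the assay rather than a number.
compound 2, `OB1OCc2ccc(-n3cccc3Sc3ccccc3Cl)cc21`, gives > 10 ug/mL, again a limit.
compound 3, `O=C(c1ccccc1)c1ccn(-c2ccc3c(c2)B(O)OC3)c1`, gives > 10 ug/mL, also a limit.

Compound 3 therefore stands exactly where the other two stand: at the limit of > 10 ug/mL in this assay, at which 3 of the 3 values shown sit. Such limits allow no ranking among the three, and no step between any two of them can be sized.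

Compound 4, `Cc1cccc(C(=O)c2ccn(-c3ccc4c(c3)B(O)OC4)c2)c1`, differs from compound 3 in one place: methyl in place of hydrogen on an aromatic carbon, which read one bond further out turns a phenyl into a 3-methylphenyl. Among the measured compounds shown here, no measured pair shows what such a change does in this setting. The expected step is a step that the limit leaves unreadable from compound 3 to compound 4, meaning no shift beyond the usual scatter, because compound 3 itself reads only as a limit > 10 ug/mL in this assay. Compound 4 is thus estimated at 20 ug/mL, within 8 ug/mL to 60 ug/mL, and most likely will again be reported only as a limit.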

Compound 4, half-maximal inhibitory concentration: > 10 ug/mL
Compound 4: a limit, no number; the forecaster's own chance of this, stated with the estimate: 75%; the middle value is on the limit's open side.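

No step from compound 3 to compound 4 can be read, because both compounds give only a limit of the assay and not a number: the limit of > 10 ug/mL in this assay, at which 4 of the 4 values shown sit.

The compounds shown leave open at what concentration any of them would inhibit these cells, and whether the added methyl changes that concentration.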